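This account rests on a few compounds, and the source may have more. Where it says the series, first, only, none or still open, it means among the compounds named here.

Compound 1 `O=S(=O)(Nc1nccs1)c1ccc2c(c1)OCC[C@H]2c1ccc(C(F)(F)F)cc1-c1nccs1` gives 3.3 in a physicochemical assay for lipophilicity; on this read-out lower numbers stand for lower lipophilicity and higher numbers for higher lipophilicity
Compound 2 `Cn1nccc1-c1cc(C(F)(F)F)ccc1[C@@H]1CCOc2cc(S(=O)(=O)Nc3nccs3)ccc21` gives 2.2 in this assay

Compound 2 has the lower of these two numbers. Compound 3 `O=S(=O)(Nc1nccs1)c1ccc2c(c1)OCC[C@H]2c1ccc(C(F)(F)F)cc1-c1ccc(F)cc1` is not yet measured and carries 4-fluorophenyl in place of 1-methyl-1H-pyrazol-5-yl on an aromatic carbon. Among the measured compounds shown here, one measured step bears on this change: a number 1.10 log units lower from compound 1 to compound 2 (beyond the scatter) is large and beyond the scatter, with 1-methyl-1H-pyrazol-5-yl replacing 1,3-thiazol-2-yl. For the measured compounds named here, no measured compound carries 4-fluorophenyl, so the size stays uncertain. A large upward move is expected, and a number 1.50 log units higher from compound 2 to compound 3 (beyond the scatter) is the estimated step. Compound 3 is estimated at 3.7 with 3.1 to 4.3 as the expected range.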

Compound 3, distribution coefficient: 4.5
Compound 3: middle estimate off by 0.80 log units, on the low side, outside the stated range (above it).
By their numbers in this assay, from the lowest: compound 2; then compound 1; then compound 3.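

In this assay, the position ortho to a large group proves highly sensitive to the choice of ring: 4-fluorophenyl in place of 1-methyl-1H-pyrazol-5-yl gives a number 2.30 log units higher from compound 2 to compound 3 (beyond the scatter) and so moves the number further than the earlier change did. Against 1,3-thiazol-2-yl, the same group gives a number 1.20 log units higher from compound 1 to compound 3 (beyond the scatter) as well, so it stands above both five-membered rings shown.

Nothing at hand accounts for the size of these steps. On these data alone, whether the fluorine or the carbon-only ring drives the rise remains open, as does the effect of an amine or a carboxylic acid on that ring.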